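Benzoxazole in Place of Cyanophenyl on the Benzyl Ether

This account rests on a few compounds, and the source may have more. Where it says the series, first, only, none or still open, it means among the compounds named here.

Measured so far:
- compound 1 `CN1CCN(CCCCOc2c(OCc3ccccc3)cc(O)c3c(=O)cc(-c4ccccc4)oc23)CC1` gives 2930 nM in a functional assay on MCF7 cells (Homo sapiens) for cytotoxicity, read by MTT assay, with a stated time of 72 h; a higher number here means a weaker inhibitor, a lower number a stronger inhibitor
- compound 2 `CN1CCN(CCCCOc2c(OCc3ccc(C#N)cc3)cc(O)c3c(=O)cc(-c4ccccc4)oc23)CC1` gives 2420 nM in this assay

Of the two numbers, compound 2 carries the smaller one, but the step of a 1.2-fold lower number from compound 1 to compound 2 (0.08 log units; within the scatter) lies within the scatter, so compound 1 and compound 2 cannot be told apart on these data.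

Compound 3 `CN1CCN(CCCCOc2c(OCc3nc4ccccc4o3)cc(O)c3c(=O)cc(-c4ccccc4)oc23)CC1` is the next variation on the same core. Its change from compound 2 is 1,3-benzoxazol-2-yl in place of 4-cyanophenyl on a saturated chain carbon bound to an oxygen on an aromatic ring. Going by the values given here, only one measured step touches this position: the step of a 1.2-fold lower number from compound 1 to compound 2 (0.08 log units; within the scatter), which put a nitrile onto the same ring and moved the number by less than the scatter. That step is small in size and concerns a different kind of change than the ring swap now in question, so it offers only weak guidance. With no evidence that alterations at this benzyl group shift the read-out, the expectation for compound 3 is a step of a 1.0-fold higher number from compound 2 to compound 3 (0.01 log units; within the scatter), that is, none beyond the scatter. Compound 3 is therefore estimated at 2500 nM, with a range from 1000 nM to 6500 nM.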

Compound 3, half-maximal inhibitory concentration: 4980 nM
The estimate for compound 3 lay 2.0-fold (0.30 log units) below the measured number; the range from low to high includes it.
By their numbers in this assay, from the lowest: compounds 2, 1 and 3 (each within the scatter of the next, the first and the last beyond it).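

Swapping 4-cyanophenyl for 1,3-benzoxazol-2-yl on a saturated chain carbon bound to an oxygen on an aromatic ring gives, in this assay, a 2.1-fold higher number from compound 2 to compound 3 (0.31 log units; beyond the scatter) and is the first step at this place to pass the scatter, so the group here can change the read-out, though only modestly. The comparison with the plain phenyl group gives a 1.7-fold higher number from compound 1 to compound 3 (0.23 log units; within the scatter) and so cannot separate those two compounds, which means the whole signal at this position rests on the single gap between the two ends of a three-compound set. Nothing measured on these compounds shows why the number moved between compound 2 and compound 3.

Still open, from the compounds shown here alone, is whether the fused six-membered ring matters, since an oxazol-2-yl group without that ring could fall with either compound 2 or compound 3, and an amine on the benzyl ring would test a quite different kind of substituent. Also open, going by these compounds, is whether the same step would hold with a longer chain in place of the one shared by all three compounds.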